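The compounds below may be only part of what the source reports. "The series", "measured", "known", "first", "only" and "open" are said of these compounds alone.

In a functional assay on A549 cells (Homo sapiens) for cytotoxicity, read by MTT assay, with a stated time of 72 h (a higher number here means a weaker inhibitor, a lower number a stronger inhibitor), two compounds built on the same core have been measured so far. Compound 1 `COC(=O)c1sc2c(C)cccc2c1Nc1cc(OC)c(OC)c(OC)c1` gives 3930 nM, while compound 2 `COC(=O)c1sc2cc(C)ccc2c1Nc1cc(OC)c(OC)c(OC)c1` gives 10.8 nM. Compound 2 therefore holds the lower of the two numbers, by a margin well beyond the usual scatter, and is the stronger inhibitor of the pair. Compound 3 `COC(=O)c1sc2ccccc2c1Nc1cc(OC)c(OC)c(OC)c1` has not yet been measured. Its structure departs from that of compound 2 by hydrogen in place of methyl on an aromatic carbon, with hydrogen in place of methyl on an aromatic carbon. Among the measured compounds shown here, no measured pair shows this change on its own, so any expectation remains loosely founded. For the measured compounds named here, the two compounds measured so far do show that numbers on this core can lie far apart, with compound 1 at 3930 nM and compound 2 at 10.8 nM. Losing the methyl is expected to raise the number beyond the scatter, though probably not as far as the value of compound 1. The expected step is an 11-fold higher number from compound 2 to compound 3 (1.05 log units; beyond the scatter). The estimate for compound 3 is 120 nM, with an expected range of 20 nM to 800 nM.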

Compound 3, half-maximal inhibitory concentration: 2850 nM
For compound 3 the middle estimate is 24-fold (1.38 log units) below the measured one; the whole stated range lies below it.
By their numbers in this assay, from the lowest: compound 2; then compounds 3 and 1 (each within the scatter of the next).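

In this assay the methyl of compound 2, on an aromatic carbon meta to a fused ring and para to a fused ring, proves decisive on this core: replacing it with hydrogen gives a 260-fold higher number from compound 2 to compound 3 (2.42 log units; beyond the scatter), a large step. The methyl of compound 1 sits on a different carbon of the same six-membered ring, and replacing that one with hydrogen gives a 1.4-fold lower number from compound 1 to compound 3 (0.14 log units; within the scatter), so there the change makes no difference that can be told from the scatter; the same exchange of methyl for hydrogen thus matters greatly at one carbon and not measurably at the other. Nothing available here offers an explanation for this dependence on place.

The compounds shown leave open whether methyl is unique at the carbon it occupies in compound 2, or whether an ethyl group, a methoxy group, a chlorine atom or an amine there would keep the number close to that of compound 2. They also leave open how a methyl group would fare on the remaining carbons of that ring.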